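This account rests on a few compounds, and the source may have more. Where it says the series, first, only, none or still open, it means among the compounds named here.

Three esters of one shared core have been measured in an ADME assay on liver (Rattus norvegicus, strain Wistar) for metabolic stability, read by HPLC, tested at 200 uM; on this read-out higher numbers stand for a longer-lived compound and lower numbers for a shorter-lived compound. Compound 1 `Cc1cc(OC(=O)C(C)(C)CCC(CO[N+](=O)[O-])O[N+](=O)[O-])n(-c2ccccc2)n1` gives 0.05 h in this assay. Compound 2 `Cc1cc(OC(=O)OCCCO[N+](=O)[O-])n(-c2ccccc2)n1` gives < 0.0167 h, which is a limit of this assay rather than a number. Compound 3 `Cc1cc(OC(=O)CCCCCO[N+](=O)[O-])n(-c2ccccc2)n1` likewise gives < 0.0167 h, again a limit of this assay and not a number. Going by the values given here, compound 3 therefore sits at the limit (the limit of < 0.0167 h in this assay, at which 2 of the 3 values shown sit), and its standing among the measured compounds cannot be set more finely than that; compound 1 is the only one with a proper number.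

Compound 4 `Cc1cc(OC(=O)CCCC(CO[N+](=O)[O-])O[N+](=O)[O-])n(-c2ccccc2)n1` is the compound still to be measured. It differs from compound 3 in one place: nitrooxy in place of hydrogen on a saturated chain carbon bound to two saturated chain carbons. Among the compounds with values here, no step between measured compounds that differ in only one place is available, so the size of this change cannot be read from a measured pair. Compound 1 also carries nitrooxy groups on its chain, but it differs from compound 4 elsewhere as well, so its value gives no direct size either. The step from compound 3 to compound 4 is expected to be an at least 1.1-fold higher number from compound 3 to compound 4 (0.07 log units; that floor lies within the scatter), toward a slightly longer-lived compound but hardly beyond the scatter. Compound 4 is estimated at 0.02 h, within a range from 0.008 h to 0.05 h, and it may again come out only as a limit of this assay.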

Compound 4, half-life in the liver assay: < 0.0167 h
Compound 4 ended at the assay's limit; the forecaster's own chance of this, stated with the estimate: 50%; middle value at least 1.1-fold (0.07 log units) away from the limit.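

In the liver assay compound 3 and compound 4 each give only a limit of the assay and not a number, so no step can be read between them: the limit of < 0.0167 h in the liver assay, at which 3 of the 4 values shown sit.

In a physicochemical assay for lipophilicity, read by HPLC, measured as octanol-water partition, at pH 7 (a lower number here means a more polar compound, a higher number a more lipophilic compound), compound 3 gives 3.79 and compound 4 gives 3.95. That is a number 0.16 log units higher from compound 3 to compound 4 (within the scatter).

The compounds shown leave open whether nitrooxy in place of hydrogen changes the half-life in the liver assay at all.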